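This account rests on a few compounds, and the source may have more. Where it says the series, first, only, none or still open, it means among the compounds named here.

Compound 1 `COc1ccc(N(Cc2ccccc2)CC(C)C)cc1` gives 10 ug/mL in a functional assay on L929 cells (Mus musculus) for inhibition, read by MTT assay, with a stated time of 5 days; on this read-out higher numbers stand for weaker inhibition and lower numbers for stronger inhibition. Compound 2 `COc1ccc(N(Cc2ccc([N+](=O)[O-])cc2)CC(C)C)cc1` reaches only the limit > 40 ug/mL in this assay. Compound 3 `Cc1ccc(N(Cc2ccccc2)CC(C)C)cc1` gives 5 ug/mL.

Compound 1 sits alongside compound 3, the pair separated by a 2.0-fold lower number from compound 1 to compound 3 (0.30 log units; within the scatter). Compound 2 is known only as a limit, (the limit of > 40 ug/mL in this assay, at which 1 of the 3 values shown sits), so the step of an at least 4.0-fold higher number from compound 1 to compound 2 (0.60 log units; beyond the scatter) is open-ended. Compound 4 `COc1ccc(N(Cc2ccccc2OC)CC(C)C)cc1` differs from compound 1 by methoxy in place of hydrogen on an aromatic carbon. Of the measured steps, an at least 4.0-fold higher number from compound 1 to compound 2 (0.60 log units; beyond the scatter) shows that adding a group on an aromatic carbon can weaken inhibition, while a 2.0-fold lower number from compound 1 to compound 3 (0.30 log units; within the scatter) shows a swap that changes little. The expected step is therefore a 1.2-fold higher number from compound 1 to compound 4 (0.08 log units; within the scatter), small and near the scatter. Compound 4 is estimated at 12 ug/mL, within 5 ug/mL to 30 ug/mL.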

Compound 4, half-maximal inhibitory concentration: 15 ug/mL
Beside the measured number, compound 4's estimate is 1.3-fold (0.10 log units) below it; the measured number falls inside the stated range.
By their numbers in this assay, from the lowest: compounds 3, 1 and 4 (each within the scatter of the next, the first and the last beyond it). At a limit, above all of these: compound 2.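

In this assay, methoxy on an aromatic carbon of this ring, ortho to a large group, gives a 1.5-fold higher number from compound 1 to compound 4 (0.18 log units; within the scatter). Adding a group to this ring therefore need not weaken inhibition, at least for methoxy at this position. Compound 2, which carries nitro on the same ring and goes against any general weakening, stays a limit: the limit of > 40 ug/mL in this assay, at which 1 of the 4 values shown sits.

From the compounds shown here alone, what remains open is whether an amine or a carboxylic acid at this position would behave like methoxy. Going by these compounds, it is also open whether methoxy elsewhere on this ring would leave inhibition as little changed.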